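Methyl to methylhydrazide on a glucose-like core

The source may hold more compounds than are shown below. What is called first, only, known or untested is meant among the compounds shown, and "the series" means these compounds.

Measured compounds:
compound 1 `C[C@H]1O[C@H](CO)[C@@H](O)[C@H](O)[C@H]1O` — 50100000 nM
compound 2 `N#CC[C@]1(O)O[C@H](CO)[C@@H](O)[C@H](O)[C@H]1O` — 7940000 nM
compound 3 `O=C(Nc1ccccc1)[C@@H]1O[C@H](CO)[C@@H](O)[C@H](O)[C@H]1O` — 5010000 nM

Three compounds sharing a sugar-like core were tested in an assay on isolated protein (Sus scrofa) for inhibition of glycogen phosphorylase, brain form (Homo sapiens); a lower number here means a stronger inhibitor, a higher number a weaker inhibitor. Compound 1 gives 50100000 nM, the highest of the three numbers. Compound 2 gives 7940000 nM, and compound 3 gives 5010000 nM; both gaps to compound 1 lie beyond the usual scatter, so compound 1 is the weakest inhibitor of this set.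

Compound 4 `CNNC(=O)[C@H]1O[C@H](CO)[C@@H](O)[C@H](O)[C@H]1O` has not yet been measured in this assay. It differs from compound 1 in one place: (methylamino)carbamoyl in place of methyl on a saturated ring carbon. Compound 3, which carries a carbamoyl-type group at a ring carbon of the same core, gives the lowest number here, which suggests that an amide-like group at that position is tolerated better than methyl. The step from compound 1 to compound 4 is therefore expected to go toward a lower number, likely of moderate size, a 5.0-fold lower number from compound 1 to compound 4 (0.70 log units; beyond the scatter). Compound 4 is estimated at 10000000 nM, with a plausible range from 3000000 nM to 40000000 nM.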

Compound 4, inhibition constant: 2000000 nM
Compound 4: middle estimate off by 5.0-fold (0.70 log units), on the high side, outside the stated range (below it).
By their numbers in this assay, from the lowest: compound 4; then compounds 3 and 2 (each within the scatter of the next); then compound 1.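

In this assay, putting (methylamino)carbamoyl in place of methyl on the saturated ring carbon next to the ring oxygen gives a 25-fold lower number from compound 1 to compound 4 (1.40 log units; beyond the scatter), a large step beyond the scatter. Among these compounds, this is the first comparison between compounds that differ in one place, so it ties a clear drop in the number to a single change at this ring carbon. The shared core therefore accepts this longer chain at that position, though nothing available here explains the size of the step.

Among the compounds shown here, the single step does not separate the contributions of the carbonyl, the two nitrogens and the end methyl within the new group. From the compounds shown here alone, whether a simple amide, a carboxylic acid or an aminomethyl group at the same ring carbon would give a similar number remains open.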